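Notes on the step from compound 1 to compound 3

The source may report more compounds than this note shows. Statements on the series, on what has been measured and on what is new or still open speak of the compounds shown alone.

Compound 1 `Cc1ccc(Nc2nc(C)c(C(=O)/C=C/c3ccc(Cl)cc3)s2)cc1` stands only at a limit in a functional assay on PC-3 cells (Homo sapiens) for cytotoxicity, read by MTT assay; a higher number here means a weaker inhibitor, a lower number a stronger inhibitor: its value > 25000 nM is a limit of the assay, not a number. In this assay compound 2 `COc1cccc(/C=C/C(=O)c2sc(Nc3ccc(Cl)c(Cl)c3)nc2C)c1` gives 10100 nM. Compound 3 `Cc1nc(Nc2cccc(Cl)c2)sc1C(=O)/C=C/c1ccc(Cl)cc1` carries the change 3-chlorophenyl in place of 4-methylphenyl on a nitrogen on an aromatic ring on the shared core. No measured step between these compounds is shown, and the limit of > 25000 nM in this assay, at which 1 of the 2 values shown sits, leaves the size of any step from compound 1 open. The step of an at least 1.6-fold lower number from compound 1 to compound 3 (0.22 log units; that floor lies within the scatter) is expected to be modest, toward a stronger inhibitor, and possibly no more than the scatter. Compound 3 is estimated at 15000 nM, within 5000 nM to 40000 nM.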

Compound 3, half-maximal inhibitory concentration: > 25000 nM
Compound 3: a limit, no number; the forecaster's own chance of this, stated with the estimate: 40%; middle value at least 1.6-fold (0.22 log units) away from the limit.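

No step from compound 1 to compound 3 can be read in this assay, because both stand only at a limit: the limit of > 25000 nM in this assay, at which 2 of the 3 values shown sit.

The compounds shown leave open whether 3-chlorophenyl in place of 4-methylphenyl changes the result in this assay at all.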